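This account rests on a few compounds, and the source may have more. Where it says the series, first, only, none or still open, it means among the compounds named here.

Working notes on the series. The shared core carries an ester-linked glycine anilide arm; compound 1 `COc1ccc(NCC(=O)Oc2ccc3c(C)cc(=O)oc3c2)cc1` and compound 2 `Cc1cc(=O)oc2cc(OC(=O)CNc3ccccc3[N+](=O)[O-])ccc12` differ only in the substituent on that anilide ring. In a functional assay on the whole organism (strain Wistar albino) for inhibition, with Rattus norvegicus as the target, read by paw edema, with stated times of 30 min and 2 h, at a dose of 20 mg/kg by the oral route (on this read-out lower numbers stand for less inhibition and higher numbers for more inhibition at the one dose given (going by the name of the read-out)), compound 1 gives 33.3%, while compound 2 gives 16.6%, the lower of the two numbers, a gap that lies beyond the usual scatter of this assay.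

Compound 3 `Cc1cc(=O)oc2cc(OC(=O)CNc3ccccc3Cl)ccc12` has not been measured. Relative to compound 2 the change is chloro in place of nitro on an aromatic carbon. Within the data shown here, no step between measured compounds covers this exchange, so nothing in the data fixes its size. With compound 2 at 16.6% as the anchor, a modest upward step is expected, a number 8.4 percentage points higher from compound 2 to compound 3 (within the scatter), of a size not clearly beyond the scatter. Compound 3 is therefore estimated at 25%, within a range from 12% to 40% in this assay.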

Compound 3, a percentage reported as inhibition, in the whole organism at one dose (the size of the read-out at that dose, not a potency): 11.5%
Estimate against measurement, compound 3: 13.5 percentage points above, outside the stated range (below it).
By their numbers in this assay, from the lowest: compounds 3 and 2 (each within the scatter of the next); then compound 1.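

For chloro in place of nitro on an aromatic carbon, ortho to a large group, this assay gives a number 5.1 percentage points lower from compound 2 to compound 3 (within the scatter), so at this position the read-out does not separate the two groups, although they differ in heavy atoms and hydrogen-bond acceptors. Exchanging the 4-methoxyphenyl on the amine nitrogen for 2-chlorophenyl gives a number 21.8 percentage points lower from compound 1 to compound 3 (beyond the scatter), which adds a second comparison in which compound 1 stands apart, but this exchange alters both the substituent and where it sits on the ring. No measurement at hand explains either result.

As far as these compounds go, whether the methoxy group itself or its place on the ring sets compound 1 apart remains open. An unsubstituted phenyl, or an amine or a carboxylic acid on that ring, would test how far this read-out responds to the anilide substituent.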